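The compounds below may be only part of what the source reports. "The series", "measured", "known", "first", "only" and "open" are said of these compounds alone.

Three compounds have so far been measured in a functional assay on SK-OV-3 cells (Homo sapiens); on this read-out lower numbers stand for stronger inhibition of growth and higher numbers for weaker inhibition of growth:

compound 1 `O=S(=O)(/C=C/c1ccc(F)cc1)Cc1ccc(Nc2ncnc3ccccc23)cc1` gives 2000 nM;
compound 2 `O=S(=O)(/C=C/c1ccc(Br)cc1)Cc1ccc(Nc2ncnc3ccccc23)cc1` gives 1000 nM;
compound 3 `O=S(=O)(/C=C/c1ccc(Cl)cc1Cl)Cc1ccc(Nc2ncnc3ccccc23)cc1` gives 2000 nM.

Compound 3 stands level with compound 1 at the digits given, the two of them together the highest numbers of the three. Its nearest neighbour is compound 1, with no change at the digits printed from compound 1 to compound 3 (within the scatter), and its furthest is compound 2, with a 2.0-fold higher number from compound 2 to compound 3 (0.30 log units; within the scatter). The remaining step, a 2.0-fold lower number from compound 1 to compound 2 (0.30 log units; within the scatter), is likewise within the scatter, so across these three compounds exchanging the substituted phenyl on the double-bonded chain carbon has moved the read-out by no more than the usual scatter.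

Compound 4 `O=S(=O)(/C=C/c1ccc(C(F)(F)F)cc1F)Cc1ccc(Nc2ncnc3ccccc23)cc1` differs from compound 3 in one place: 2-fluoro-4-(trifluoromethyl)phenyl in place of 2,4-dichlorophenyl on a double-bonded chain carbon bound to a double-bonded chain carbon. Within the data shown here, no measured step carries this exact exchange, but all three measured steps swap one substituted phenyl for another at the same place and none of them left the scatter. In this assay the expected change is therefore no change at the digits printed from compound 3 to compound 4 (within the scatter), nothing beyond the scatter. Compound 4 is estimated at 2000 nM, with a range from 800 nM to 5000 nM.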

Compound 4, concentration for 50% growth inhibition: 39000 nM
Compound 4: middle estimate off by 20-fold (1.29 log units), on the low side; measured number outside the range, above it.
By their numbers in this assay, from the lowest: compounds 2, 1 and 3 (each within the scatter of the next); then compound 4.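

In this assay, among these compounds, the place on the double-bonded chain carbon proved far less tolerant than the earlier compounds had suggested: 2-fluoro-4-(trifluoromethyl)phenyl brought a 20-fold higher number from compound 3 to compound 4 (1.29 log units; beyond the scatter), a 20-fold higher number from compound 1 to compound 4 (1.29 log units; beyond the scatter) and a 39-fold higher number from compound 2 to compound 4 (1.59 log units; beyond the scatter), whereas the steps among compound 1, compound 2 and compound 3 all stayed within the scatter. Exchanging one substituted phenyl for another at this place is therefore not neutral in every case, and the size of the change depends on which substituents enter. Nothing at hand accounts for this large step.

The compounds shown do not separate the fluoro from the trifluoromethyl within the entering group, which a phenyl carrying only one of the two could do. On these data alone, how a plain phenyl, or a phenyl carrying a methoxy group or an amine, would behave at this place also remains open.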